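Trimming One Carbon from a Selenium-Bearing Group

The compounds below may be only part of what the source reports. "The series", "measured", "known", "first", "only" and "open" are said of these compounds alone.

Measured compounds:
Compound 1, `COc1ccc(N(C)c2nc(C)nc3ccccc23)cc1OCCN`: 343 nM
Compound 2, `COc1ccc(N(C)c2nc(C)nc3ccccc23)cc1C[Se]C#N`: 1110 nM

For the measured compounds named here, in a functional assay on HepG2 cells (Homo sapiens) for inhibition, read by MTT assay, with a stated time of 48 h (on this read-out higher numbers stand for weaker inhibition and lower numbers for stronger inhibition), compound 2 gives 1110 nM, the highest of the two numbers measured so far. Its nearest neighbour is compound 1, and the change between them, a 3.2-fold higher number from compound 1 to compound 2 (0.51 log units; beyond the scatter), swapped one group of four heavy atoms for another at an aromatic carbon of the shared core.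

Compound 3, `COc1ccc(N(C)c2nc(C)nc3ccccc23)cc1[Se]C#N`, is not yet measured. It differs from compound 2 in one place: a group of 3 heavy atoms (1 carbon, 1 nitrogen, 1 selenium; no ring) in place of a group of 4 heavy atoms (2 carbon, 1 nitrogen, 1 selenium; no ring), on an aromatic carbon. The group that leaves and the group that enters share the selenium atom and the triple bond, so the change amounts to dropping a single carbon from the chain.

Going by the values given here, only one measured step exists, and it concerns a different kind of swap, exchanging an oxygen-linked chain for a selenium-linked one. Among the compounds with values here, no measured step removes a carbon from a chain of this kind, so there is no direct guide. Given that, the step of a 1.1-fold lower number from compound 2 to compound 3 (0.05 log units; within the scatter) is expected to stay within the scatter, with no clear direction. Compound 3 is estimated at 1000 nM, within a range from 350 nM to 2900 nM.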

Compound 3, half-maximal inhibitory concentration: 59 nM
Estimate against measurement, compound 3: 17-fold (1.23 log units) above; measured number outside the range, below it.
By their numbers in this assay, from the lowest: compound 3; then compound 1; then compound 2.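

In this assay, dropping one carbon from the selenium-bearing group on an aromatic carbon ortho to a methoxy group gives a 19-fold lower number from compound 2 to compound 3 (1.27 log units; beyond the scatter) and shows that this position responds strongly to a very small change in the group. It also reverses the comparison with the oxygen-linked chain: a 3.2-fold higher number from compound 1 to compound 2 (0.51 log units; beyond the scatter) is the result for the longer selenium group, whereas the shorter one gives a 5.8-fold lower number from compound 1 to compound 3 (0.76 log units; beyond the scatter), so the presence of selenium alone does not set the direction at this position, and the carbon count of the group matters as well. Nothing available here accounts for the size of this drop in the number.

On these data alone, it remains open whether selenium itself is needed for the low number of compound 3 or whether a thiocyanate, with sulfur in its place, or a nitrile attached directly to the aromatic carbon would do the same. For the compounds shown here, a longer chain carrying two carbons ahead of the selenium would also show whether the numbers keep rising as the group grows or whether the single added carbon of compound 2 is a special case.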